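Branching the Alkyl Chain on a Cyanoaziridine Urea

The source may report more compounds than this note shows. Statements on the series, on what has been measured and on what is new or still open speak of the compounds shown alone.

Compound 1 `CCCCNC(=O)N1CC1C#N` is a cyanoaziridine urea carrying a butyl group on its amide-type nitrogen. In a functional assay on L1210 cells (Mus musculus) for inhibition, read by MTT assay (a higher number here means a weaker inhibitor, a lower number a stronger inhibitor), compound 1 gives 12000 nM. For the measured compounds named here, it stands at the higher of the two numbers recorded; its only neighbour, compound 2 `CC(=O)c1cccc(NC(=O)N2CC2C#N)c1`, gives 7900 nM, a difference that lies within the scatter of the measurement, so no order between the two can be claimed. Compound 3 `CC(C)(C)NC(=O)N1CC1C#N` has not yet been measured in this assay. It differs from compound 1 in a single place: tert-butyl in place of butyl on an amide-type nitrogen. Going by the values given here, no comparable step between measured compounds is available to calibrate this change, and the two measured values give no direction for it. Compound 3 is therefore expected to land close to compound 1, with a step of a 1.1-fold higher number from compound 1 to compound 3 (0.03 log units; within the scatter) that stays within the scatter. The estimate for compound 3 is 13000 nM, with a range from 5000 nM to 35000 nM.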

Compound 3, half-maximal inhibitory concentration: 457000 nM
Compound 3: the middle estimate sits 35-fold (1.55 log units) below what was measured, outside the stated range (above it).
By their numbers in this assay, from the lowest: compounds 2 and 1 (each within the scatter of the next); then compound 3.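

In this assay, tert-butyl in place of butyl brings a 38-fold higher number from compound 1 to compound 3 (1.58 log units; beyond the scatter) and so a far weaker inhibitor, even though the two groups have the same number of carbons. Neither group adds a ring, a hydrogen-bond donor, a hydrogen-bond acceptor or a charge, so this position on the amide-type nitrogen distinguishes how these carbons are joined, not merely how many there are. Nothing available accounts for the size of this step.

The compounds shown leave open whether the loss already appears with a smaller branched group such as isopropyl or sec-butyl, or only with tert-butyl. They also do not show whether a longer chain such as hexyl, or a cyclobutyl group, would stay close to compound 1 or fall away as compound 3 does.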